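The compounds below may be only part of what the source reports. "The series", "measured", "known", "first", "only" and "open" are said of these compounds alone.

Compound 2 `COc1cccc(C(C)Sc2nc3c(cnn3C)c(=O)n2-c2ccccc2)c1` stands lowest of the three numbers in an assay on isolated protein for inhibition of Retinaldehyde dehydrogenase 3 (Homo sapiens) (a higher number here means a weaker inhibitor, a lower number a stronger inhibitor), where compound 2 gives 174 nM. Compound 3 `C#Cc1ccc(-n2c(SC(C)c3ccccc3)nc3c(cnn3C)c2=O)cc1` lies nearest to it, and in this assay compound 3 gives 520 nM. Compound 1 `CC(Sc1nc2c(cnn2C)c(=O)n1-c1ccc(CCO)cc1)c1ccccc1` lies furthest away, and in this assay compound 1 gives 3000 nM. Going by the values given here, the one measured step that alters a single place, a 5.8-fold lower number from compound 1 to compound 3 (0.76 log units; beyond the scatter), concerns the ring on the nitrogen of the shared core, not the ring on the sulfur-bearing carbon. Compound 4 `COc1ccccc1C(C)Sc1nc2c(cnn2C)c(=O)n1-c1ccccc1` differs from compound 2 by 2-methoxyphenyl in place of 3-methoxyphenyl on a saturated chain carbon bound to a saturated chain carbon and a sulfur. Among the compounds with values here, no measured step touches this place, so the only guidance is that compound 2, which carries the 3-methoxyphenyl group, gives the lowest number seen at 174 nM. The change to 2-methoxyphenyl is expected to move the number by a 1.4-fold higher number from compound 2 to compound 4 (0.16 log units; within the scatter), a step not beyond the scatter. Compound 4 is therefore estimated at 250 nM, with a range from 80 nM to 800 nM.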

Compound 4, half-maximal inhibitory concentration: 112 nM
Estimate against measurement, compound 4: 2.2-fold (0.35 log units) above; low and high end bracket the measured number.
By their numbers in this assay, from the lowest: compounds 4 and 2 (each within the scatter of the next); then compound 3; then compound 1.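

Going by these compounds alone, this is the first measured step at the saturated chain carbon bound to a saturated chain carbon and a sulfur: in this assay, 2-methoxyphenyl in place of 3-methoxyphenyl gives a 1.6-fold lower number from compound 2 to compound 4 (0.19 log units; within the scatter), so this assay does not separate the two groups. Compound 2 and compound 4 therefore stand together, and the methoxy group can sit at either of these two printed places on this ring without a change that can be read. No measured evidence here offers an explanation for this result.

The compounds shown leave open what a hydroxyl or an ethoxy group in place of the methoxy group would give at this place. They also leave open whether the same step would read alike with ethynyl or 2-hydroxyethyl on the ring on the nitrogen of the shared core.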